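Cytotoxicity notes on a phthalimide-ethyl thiocarbamate series

This account rests on a few compounds, and the source may have more. Where it says the series, first, only, none or still open, it means among the compounds named here.

Of the compounds shown here, three have been tested in an ADME assay on MT4 cells (Homo sapiens) for cytotoxicity, read by MTT assay; a lower number here means that less compound is tolerated, a higher number that more compound is tolerated. Compound 1 (`Cc1ccc(C(=O)N(C(=S)OCCN2C(=O)c3ccccc3C2=O)c2ccc(Cl)cc2)cc1`) reaches only the limit of > 100000 nM in this assay, not a number. Compound 3 (`Cc1ccc(N(C(=O)c2ccccc2C)C(=S)OCCN2C(=O)c3ccccc3C2=O)cc1`) likewise sits at the limit of > 100000 nM in this assay. Compound 2 (`O=C1c2ccccc2C(=O)N1CCOC(=S)N(C(=O)c1ccc(Br)cc1)c1ccc(Br)cc1`) gives a number, 73000 nM in this assay. Two of the three values sit at the limit of > 100000 nM in this assay, at which 2 of the 3 values shown sit, so compound 1 can only be placed at that limit.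

Compound 4 (`O=C1c2ccccc2C(=O)N1CCOC(=S)N(C(=O)c1ccc(Cl)cc1Cl)c1ccc(Cl)cc1`) has not yet been measured. It differs from compound 1 by 2,4-dichlorophenyl in place of 4-methylphenyl on a carbonyl carbon. With compound 2 at 73000 nM as the one numeric point, compound 4 is expected to come out near that range, so the step of an at least 1.2-fold lower number from compound 1 to compound 4 (0.09 log units; that floor lies within the scatter) is estimated as small, if any. Compound 4 is thus expected to give about 80000 nM in this assay, within 30000 nM to 200000 nM.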

Compound 4, half-maximal cytotoxic concentration: 18000 nM
Estimate against measurement, compound 4: 4.4-fold (0.65 log units) above, outside the stated range (below it).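

In this assay, within the data shown here, the change from 4-methylphenyl to 2,4-dichlorophenyl on a carbonyl carbon gives an at least 5.5-fold lower number from compound 1 to compound 4 (0.74 log units; beyond the scatter) and is the first step that can be read. The aryl group at this place, on a carbonyl carbon whose other neighbour is the amide-type nitrogen, therefore matters for the concentration tolerated. The value of compound 1 is a limit and not a number, so the size of this step is only a floor: the limit of > 100000 nM in this assay, at which 2 of the 4 values shown sit.

On these data alone, whether one chlorine alone, as in 4-chlorophenyl, would carry the step stays open. So does the outcome with an amine or a carboxylic acid on that aromatic ring.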